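This account rests on a few compounds, and the source may have more. Where it says the series, first, only, none or still open, it means among the compounds named here.

Two compounds of the series have numbers in a functional assay on MIA PaCa-2 cells (Homo sapiens) for inhibition, read by MTT assay, with a stated time of 7 days; on this read-out lower numbers stand for stronger inhibition and higher numbers for weaker inhibition. Compound 2 `O=C([C@@H]1CCCN(S(=O)(=O)c2ccc(S(=O)(=O)C3CC3)cc2)C1)N1CCC(F)(F)CC1` gives 26 nM in this assay, the lowest of the two. Among the measured compounds shown here, compound 1 `CCN(CC)S(=O)(=O)c1ccc(S(=O)(=O)N2CCC[C@@H](C(=O)NC3CCOCC3)C2)cc1` gives 3770 nM in this assay, a gap beyond the scatter; compound 1 differs from compound 2 in more than one place, so no single step connects them. Compound 3 `CCN(CC)S(=O)(=O)c1ccc(S(=O)(=O)N2CCC[C@@H](C(=O)N3CCC(F)(F)CC3)C2)cc1` differs from compound 2 in one place: diethylamino in place of cyclopropyl on a sulfonyl sulfur. A weakening is expected because in this assay compound 1 with the same diethylsulfamoyl group gives 3770 nM. For compound 3 an estimated 5.8-fold higher number from compound 2 to compound 3 (0.76 log units; beyond the scatter) is expected, giving 150 nM (30 nM to 800 nM).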

Compound 3, half-maximal inhibitory concentration: 16 nM
Beside the measured number, compound 3's estimate is 9.4-fold (0.97 log units) above it; the whole stated range lies above it.
By their numbers in this assay, from the lowest: compounds 3 and 2 (each within the scatter of the next); then compound 1.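

In this assay the sulfonyl sulfur takes diethylamino as well as cyclopropyl, with a 1.6-fold lower number from compound 2 to compound 3 (0.21 log units; within the scatter). The large difference lies at the carbonyl carbon instead: 4,4-difluoropiperidin-1-yl in place of (oxan-4-yl)amino gives a 240-fold lower number from compound 1 to compound 3 (2.37 log units; beyond the scatter), so the weak number of compound 1 does not follow from the diethylsulfamoyl group alone. No measurement here accounts for either step.

Still open, as far as these compounds go, is how morpholin-4-yl or a longer chain such as butyl would read on the sulfonyl sulfur. Also open, from the compounds shown here alone, is how piperidin-1-yl without fluorine would read on the carbonyl carbon.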